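A few compounds are considered here, and "the series" means these few. Any claim that something is new, unique, unknown or untested is made for them only; others in the source may bear on it.

Measured in a functional assay on HeLa cells (Homo sapiens) for cytotoxicity, read by WST assay, with a stated time of 48 h; a lower number here means a stronger inhibitor, a higher number a weaker inhibitor:
- compound 1 `COc1cccc([C@H](O)[C@H]2CO[C@H](c3ccc(OC)c(OC)c3)[C@@H](C/C=C/c3ccc(OC)c(OC)c3)C2)c1`: 21200 nM
- compound 2 `O=[N+]([O-])c1cccc(/C=C/C[C@H]2C[C@@H]([C@@H](O)c3ccccc3)CO[C@@H]2c2ccccc2)c1`: 7850 nM

Of these two, compound 2 has the lower number and so is the stronger inhibitor, and the gap to compound 1 lies beyond the usual scatter.

Compound 3 `O[C@@H](c1ccccc1)[C@H]1CO[C@H](c2ccccc2)[C@@H](C/C=C/c2ccc(F)cc2)C1` has not yet been measured. It differs from compound 2 in one place, with 4-fluorophenyl in place of 3-nitrophenyl on a double-bonded chain carbon bound to a double-bonded chain carbon. For the measured compounds named here, no measured pair of compounds shows this change, so the only guides are compound 2 at 7850 nM and compound 1 at 21200 nM. A small rise in the number, not clearly beyond the scatter in this assay, is expected, and the estimated step is a 1.4-fold higher number from compound 2 to compound 3 (0.15 log units; within the scatter). The estimate for compound 3 is 11000 nM, with an expected range of 4500 nM to 26000 nM.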

Compound 3, half-maximal inhibitory concentration: 8340 nM
Estimate against measurement, compound 3: 1.3-fold (0.12 log units) above, within the range that was stated.
By their numbers in this assay, from the lowest: compounds 2 and 3 (each within the scatter of the next); then compound 1.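

In this assay, 4-fluorophenyl in place of 3-nitrophenyl on a double-bonded chain carbon bound to a double-bonded chain carbon gives a 1.1-fold higher number from compound 2 to compound 3 (0.03 log units; within the scatter). For the compounds shown here, this is the first direct reading at this position, and it shows that these two groups cannot be told apart here, although they differ in both the substituent and its place on the phenyl ring. The step does not separate those two differences, and nothing available accounts for the outcome.

The compounds shown leave open whether a plain phenyl, or a phenyl carrying an amine or a carboxylic acid, at this place would give a number beyond the scatter of these two. They also leave open whether 3-fluorophenyl or 4-nitrophenyl would behave in the same way.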